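This account rests on a few compounds, and the source may have more. Where it says the series, first, only, none or still open, it means among the compounds named here.

Of the compounds shown here, two have been measured in an assay on lung parenchyma (Cavia porcellus) for displacement of a labelled ligand from cysteinyl leukotriene receptor (Homo sapiens); a higher number here means a weaker inhibitor, a lower number a stronger inhibitor. Compound 1 `COc1cc(C(=O)NS(=O)(=O)c2ccccc2)ccc1Cc1cn(C)c2ccc(NC(=O)OC3CCCC3)cc12` carries a (phenylsulfonyl)carbamoyl group on its aromatic core, and in this assay compound 1 gives 0.8 nM. Compound 2 `COc1cc(C(=O)O)ccc1Cc1cn(C2CCCC2)c2ccc(NC(=O)OC3CCCC3)cc12` carries a plain carboxy group instead and a different substituent on the indole nitrogen; in this assay compound 2 gives 53 nM, the higher of the two numbers and therefore the weaker binder of the pair. Compound 3 `COc1cc(C(=O)NS(=O)(=O)c2ccccc2)ccc1Cc1cn(C2CCCC2)c2ccc(NC(=O)OC3CCCC3)cc12` is the change of compound 2 at one place only: (phenylsulfonyl)amino in place of hydroxy on a carbonyl carbon. Going by the values given here, no measured pair isolates exactly this change, so the expectation rests on the fact that compound 1, which carries the same (phenylsulfonyl)carbamoyl group, gives 0.8 nM. The step of an 18-fold lower number from compound 2 to compound 3 (1.25 log units; beyond the scatter) is expected to be a clear move toward a lower number, beyond the scatter. Compound 3 is estimated at 3 nM, within a range from 0.8 nM to 12 nM.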

Compound 3, inhibition constant: 67 nM
Estimate against measurement, compound 3: 22-fold (1.35 log units) below; the whole stated range lies below it.
By their numbers in this assay, from the lowest: compound 1; then compounds 2 and 3 (each within the scatter of the next).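

With cyclopentyl on the aromatic nitrogen, placing (phenylsulfonyl)amino instead of hydroxy on the carbonyl carbon gives a 1.3-fold higher number from compound 2 to compound 3 (0.10 log units; within the scatter) in this assay, so here this swap makes no difference that can be told from scatter, and the low number of compound 1 does not come from that group alone. Going by these compounds alone, the group on the aromatic nitrogen matters strongly: cyclopentyl in place of methyl gives an 84-fold higher number from compound 1 to compound 3 (1.92 log units; beyond the scatter), a change that no earlier pair isolated. Nothing available explains either result.

The compounds shown leave open whether the swap on the carbonyl carbon would count for more with methyl on the aromatic nitrogen. They also leave open how an ethyl, a propyl or a cyclopropyl group on that nitrogen would read in this assay.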